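The source may hold more compounds than are shown below. What is called first, only, known or untested is meant among the compounds shown, and "the series" means these compounds.

Measured so far in a functional assay on HT-29 cells (Homo sapiens) for antiproliferative activity, read by sulforhodamine B assay, with a stated time of 48 h; a lower number here means a stronger inhibitor, a higher number a weaker inhibitor:
compound 1, `CCCCCCCc1ccc(NS(=O)(=O)c2ccc(N3CCNC3=O)cc2)cc1`: > 1000 nM
compound 2, `O=C1NCCN1c1ccc(S(=O)(=O)Nc2ccc(F)c(F)c2)cc1`: 350 nM
compound 3, `CC(C)(C)c1cc(NS(=O)(=O)c2ccc(N3CCNC3=O)cc2)cc(C(C)(C)C)c1`: > 1000 nM

In this assay, for the measured compounds named here, compound 2 gives 350 nM, the only number in the set. For compound 1 the result is a limit, > 1000 nM. For compound 3 the result is likewise a limit, > 1000 nM. Together these two make up (the limit of > 1000 nM in this assay, at which 2 of the 3 values shown sit).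

Compound 4, `COc1ccccc1NS(=O)(=O)c1ccc(N2CCNC2=O)cc1`, has not been measured. It differs from compound 2 by 2-methoxyphenyl in place of 3,4-difluorophenyl on a sulfonamide nitrogen. Going by the values given here, no step between measured compounds is available to guide the size; the expected step of a 1.7-fold higher number from compound 2 to compound 4 (0.23 log units; within the scatter) is a small loss, near the edge of the scatter, with a real chance that only a limit is returned. Compound 4 is estimated at 600 nM, with a range from 200 nM to 2000 nM.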

Compound 4, half-maximal inhibitory concentration: 550 nM
Compound 4: middle estimate off by 1.1-fold (0.04 log units), on the high side; the range from low to high includes it.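

In this assay, for the compounds shown here, 2-methoxyphenyl in place of 3,4-difluorophenyl on a sulfonamide nitrogen gives a 1.6-fold higher number from compound 2 to compound 4 (0.20 log units; within the scatter), the first readable step. At this position, two differently substituted phenyl groups therefore cannot be told apart, even though the entering group carries a hydrogen-bond acceptor and the leaving group none. Compound 4, like compound 2, returns a number rather than a limit, unlike the other two compounds: the limit of > 1000 nM in this assay, at which 2 of the 4 values shown sit.

From the compounds shown here alone, what an unsubstituted phenyl, a pyridine or an aminophenyl group would give on this nitrogen remains open. Whether the methoxy group itself matters, or a methoxy group elsewhere on the ring would give the same result, is also unresolved.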